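Methyl in Place of Methoxy on the Aromatic Ring

A few compounds are considered here, and "the series" means these few. Any claim that something is new, unique, unknown or untested is made for them only; others in the source may bear on it.

Compound 1 `O=C(CCCCCc1cccc(Br)c1)N1CCOC1=O`, compound 2 `O=C(CCCCCc1ccc(O)cc1)N1CCOC1=O` and compound 3 `COc1ccc(CCCCCC(=O)N2CCOC2=O)cc1` share one core and differ only in the group on the aromatic ring. In an assay on HEK293 cells for inhibition of N-acylethanolamine-hydrolyzing acid amidase (Rattus norvegicus), read by LC-MS, with a stated time of 30 min (on this read-out higher numbers stand for weaker inhibition and lower numbers for stronger inhibition), compound 1 gives 430 nM. In this assay compound 2 gives 61 nM. Compound 3 reaches only the limit of this assay, reported as > 20000 nM, which is a limit and not a number (the limit of > 20000 nM in this assay, at which 1 of the 3 values shown sits). Compound 3 therefore stands at the weak end of the three, and the step of an at least 320-fold higher number from compound 2 to compound 3 (2.51 log units; beyond the scatter) shows how much a single small change on this ring can move the result.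

Compound 4 `Cc1ccc(CCCCCC(=O)N2CCOC2=O)cc1` differs from compound 3 by methyl in place of methoxy on an aromatic carbon. For the measured compounds named here, no measured step covers this exact change. Going by the values given here, the only step that bears on it is an at least 320-fold higher number from compound 2 to compound 3 (2.51 log units; beyond the scatter), and compound 1, which carries no hydroxyl, still gives 430 nM. Compound 4 is therefore expected to recover part of the lost inhibition, a step of an at least 6.6-fold lower number from compound 3 to compound 4 (0.82 log units; beyond the scatter). For compound 4 the expected value in this assay is 3000 nM, with a range from 400 nM to 20000 nM.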

Compound 4, half-maximal inhibitory concentration: 440 nM
Estimate against measurement, compound 4: 6.8-fold (0.83 log units) above; the range from low to high includes it.
By their numbers in this assay, from the lowest: compound 2; then compounds 1 and 4 (each within the scatter of the next). At a limit, above all of these: compound 3.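

In this assay, the step of an at least 45-fold lower number from compound 3 to compound 4 (1.65 log units; beyond the scatter) shows that the sharp loss seen with methoxy does not extend to every group in place of the hydroxy on this aromatic carbon, para to a large group, even though methoxy and methyl both count 0 hydrogen-bond donors. Methyl does not fully match hydroxy at this place, with a 7.2-fold higher number from compound 2 to compound 4 (0.86 log units; beyond the scatter). Compound 3 stands at a limit, so the step from it gives a bound and not a size: the limit of > 20000 nM in this assay, at which 1 of the 4 values shown sits.

The compounds shown leave open whether the loss belongs to the oxygen of methoxy or to its extra heavy atom, a question that an ethyl group at the same place would bear on. Going by these compounds, how an amine or a carboxylic acid would behave there also stays open.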